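Chloro for Fluoro on the Benzylidene Ring

The source may hold more compounds than are shown below. What is called first, only, known or untested is meant among the compounds shown, and "the series" means these compounds.

Compound 1, `CN(C)CCn1cnnc1-c1cc(Oc2ccc(NC(=O)N/N=C/c3ccc(Cl)cc3Cl)cc2F)ccn1`: 2330 nM
Compound 2, `CN(C)CCn1cnnc1-c1cc(Oc2ccc(NC(=O)N/N=C/c3ccc(F)cc3F)cc2F)ccn1`: 1900 nM

In a functional assay on U-87MG ATCC cells (Homo sapiens) for cytotoxicity, read by MTT assay, with a stated time of 72 h (a lower number here means a stronger inhibitor, a higher number a weaker inhibitor), compound 2 gives 1900 nM, the lower of the two numbers shown, although its gap to compound 1 lies within the scatter. Compound 1 gives 2330 nM in this assay, and the step of a 1.2-fold lower number from compound 1 to compound 2 (0.09 log units; within the scatter) does not allow any real order between the two compounds to be read.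

Compound 3, `CN(C)CCn1cnnc1-c1cc(Oc2ccc(NC(=O)N/N=C/c3ccc(F)cc3Cl)cc2F)ccn1`, has not been measured. It differs from compound 2 by chloro in place of fluoro on an aromatic carbon. For the measured compounds named here, the only measured step that bears on this change is a 1.2-fold lower number from compound 1 to compound 2 (0.09 log units; within the scatter), in which both chloro groups were exchanged for fluoro and the number moved only a little. Compound 3 carries one chloro and one fluoro and so sits in structure between compound 1 and compound 2. A step smaller than the measured one, and in the reverse direction, is therefore expected, which remains within the scatter. The expected step is a 1.1-fold higher number from compound 2 to compound 3 (0.04 log units; within the scatter). Compound 3 is estimated to give 2100 nM in this assay. For compound 3 the expected range runs from 1000 nM to 4500 nM.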

Compound 3, half-maximal inhibitory concentration: 1210 nM
Compound 3: middle estimate off by 1.7-fold (0.24 log units), on the high side, and the stated range covers the measured number.
By their numbers in this assay, from the lowest: compounds 3, 2 and 1 (each within the scatter of the next).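

In this assay, the earlier pair showed only the two halogens exchanged together, whereas the 2-chloro-4-fluorophenyl group now lets each exchange be read singly. Chloro in place of fluoro on the aromatic carbon ortho to a large group gives a 1.6-fold lower number from compound 2 to compound 3 (0.20 log units; within the scatter), and the exchange of fluoro for chloro at the other halogen site gives a 1.9-fold lower number from compound 1 to compound 3 (0.28 log units; within the scatter). Neither single exchange moves the number beyond the scatter, so no real order among the three compounds can be read, and nothing available explains the size of either step.

The compounds shown carry only chloro and fluoro on this ring, so it remains open whether a methoxy group, an amine or a carboxylic acid on the same aromatic carbon would give a step beyond the scatter in this assay. As far as these compounds go, it also remains open whether a plain hydrogen at that carbon would leave the number within the scatter of these three compounds, and whether the same exchanges would behave alike on a different core.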